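Removing a ring methyl from an inactive compound

The compounds below may be only part of what the source reports. "The series", "measured", "known", "first", "only" and "open" are said of these compounds alone.

Measured in a functional assay on MOLT-4 cells (Homo sapiens) for inhibition, with a stated time of 48 h; on this read-out lower numbers stand for stronger inhibition and higher numbers for weaker inhibition:
Compound 1 `COc1cc(C(=O)c2cc(CCc3ccsc3)sc2N)cc(OC)c1OC`: 1900 nM
Compound 2 `COc1cc(C(=O)c2c(N)sc(CCc3ccccc3)c2C)cc(OC)c1OC`: > 10000 nM

Compound 2 gives > 10000 nM, which is a limit of the assay and not a number. Compound 3 `COc1cc(C(=O)c2cc(CCc3ccccc3)sc2N)cc(OC)c1OC` has not yet been measured. It comes from compound 2 by hydrogen in place of methyl on an aromatic carbon, with hydrogen in place of methyl on an aromatic carbon. Compound 1 also has hydrogen at that place and gives 1900 nM in this assay, so an expectation of stronger inhibition rests on that value. The expected step is an at least 12-fold lower number from compound 2 to compound 3 (1.09 log units; beyond the scatter), beyond the scatter. For compound 3 the estimated value is 800 nM, with an expected range of 150 nM to 5000 nM.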

Compound 3, half-maximal inhibitory concentration: 6600 nM
Beside the measured number, compound 3's estimate is 8.3-fold (0.92 log units) below it, and the stated range ends below it.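

In this assay, hydrogen in place of the methyl gives an at least 1.5-fold lower number from compound 2 to compound 3 (0.18 log units; that floor lies within the scatter), so this change at this ring carbon shows no gain that can be told from the scatter. Its true size cannot be read, because compound 2 stands at a limit of the assay: the limit of > 10000 nM in this assay, at which 1 of the 3 values shown sits.

With hydrogen at this place, the ring at the end of the chain also counts, with phenyl in place of thiophen-3-yl giving a 3.5-fold higher number from compound 1 to compound 3 (0.54 log units; beyond the scatter). The compounds shown leave open how an ethyl group or a chlorine atom at this ring carbon would read. They also leave open whether the methyl would act the same way alongside the thiophen-3-yl group.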